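This account rests on a few compounds, and the source may have more. Where it says the series, first, only, none or still open, it means among the compounds named here.

Compound 1: `C/C(=C\c1cc(-c2cccnc2)co1)C(N)=O` gives 8640 nM in a functional assay on HO8910 cells (Homo sapiens) for cytotoxicity, read by CCK-8 assay, with a stated time of 24 h; a higher number here means a weaker inhibitor, a lower number a stronger inhibitor.
Compound 2: `C/C(=C\c1ccc(-c2ccc(C)cc2)o1)C(N)=O` gives 1660 nM in this assay.

Of the two measured compounds, compound 2 has the lower number, and compound 1 stands a clear distance above it, beyond the usual scatter; the two share the same amide-bearing chain on a furan, but differ in both the ring attached to that furan and the point of attachment, so nothing links them as a single change.

Compound 3 is `C/C(=C\c1ccc(-c2ccc(F)cc2)o1)C(N)=O`. It differs from compound 2 only in one place: fluoro in place of methyl on an aromatic carbon. Among the measured compounds shown here, no measured pair here shows what this kind of exchange does. The two groups are of like size, and with nothing in the measured compounds to say otherwise, the step from compound 2 is expected to be small, in either direction, and most likely within the scatter. The expected step is a 1.4-fold higher number from compound 2 to compound 3 (0.16 log units; within the scatter). Compound 3 is therefore estimated at 2400 nM, with a likely range from 900 nM to 7000 nM.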

Compound 3, half-maximal inhibitory concentration: 990 nM
For compound 3 the middle estimate is 2.4-fold (0.38 log units) above the measured one, within the range that was stated.
By their numbers in this assay, from the lowest: compounds 3 and 2 (each within the scatter of the next); then compound 1.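

Among the compounds shown here, the exchange of methyl for fluoro on an aromatic carbon, para to a large group, gives the first single-place comparison here: in this assay it produces a 1.7-fold lower number from compound 2 to compound 3 (0.22 log units; within the scatter) and so cannot be told apart from repeat measurement. For the compounds shown here, at this position, then, the two one-atom groups give numbers that cannot be put in order, which the earlier compounds could not show. Nothing measured on these compounds speaks to why the two groups read alike.

As far as these compounds go, it remains open whether another group at this position, such as an amine, a carboxylic acid or a longer chain, would shift the number beyond the scatter. The gap to compound 1 also stays unassigned, since that compound differs from compound 2 in more than one place.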